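Halogen swap on the benzoyl ring of a coumarin hydrazide

This account rests on a few compounds, and the source may have more. Where it says the series, first, only, none or still open, it means among the compounds named here.

Of the compounds shown here, two sharing one core have been measured in a functional assay on DLA cells (Mus musculus) for cytotoxicity, read by trypan blue exclusion, with a stated time of 48 h; a higher number here means a weaker inhibitor, a lower number a stronger inhibitor. Compound 1 `COc1ccc(C(=O)c2cc(C)ccc2OCC(=O)NNC(=O)c2cc3ccccc3oc2=O)cc1` gives 43500 nM. Compound 2 `Cc1ccc(OCC(=O)NNC(=O)c2cc3ccccc3oc2=O)c(C(=O)c2ccc(Cl)cc2)c1` gives 61600 nM, the higher of the two numbers, yet the step of a 1.4-fold higher number from compound 1 to compound 2 (0.15 log units; within the scatter) is within the scatter, so the two cannot be ordered.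

Compound 3 `Cc1ccc(OCC(=O)NNC(=O)c2cc3ccccc3oc2=O)c(C(=O)c2cccc(Br)c2)c1` has not yet been measured. It differs from compound 2 by a single change: 3-bromophenyl in place of 4-chlorophenyl on a carbonyl carbon. Among the compounds with values here, only one measured step exists, and it bears on this change only loosely: it also exchanged one substituent on an aromatic carbon of the same part of the molecule, and it stayed within the scatter. Within the data shown here, no measured pair shows a chloro-for-bromo exchange or a shift of a halogen from one carbon to another, so there is nothing to point to a large move in either direction.

In this assay compound 3 is therefore expected to read close to compound 2, with the step of a 1.1-fold lower number from compound 2 to compound 3 (0.05 log units; within the scatter) expected to stay within the scatter, giving an estimated 55000 nM in a range from 25000 nM to 120000 nM.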

Compound 3, half-maximal inhibitory concentration: 71900 nM
Beside the measured number, compound 3's estimate is 1.3-fold (0.12 log units) below it; the measured number falls inside the stated range.
By their numbers in this assay, from the lowest: compounds 1, 2 and 3 (each within the scatter of the next).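

In this assay, putting 3-bromophenyl in place of 4-chlorophenyl on the carbonyl carbon gives a 1.2-fold higher number from compound 2 to compound 3 (0.07 log units; within the scatter), and putting it in place of 4-methoxyphenyl at the same carbon gives a 1.7-fold higher number from compound 1 to compound 3 (0.22 log units; within the scatter). This carbon has now carried three different substituted phenyl groups, and no two of them can be told apart in this assay, so the earlier single comparison has become a small set of three that all agree within the scatter. Even a step that exchanges the halogen and also alters the number in the group's name leaves the reading within the scatter, but nothing measured explains this sameness.

On these data alone, that step made both alterations at once, so 3-chlorophenyl or 4-bromophenyl would be needed to look at each alone, and their readings remain open. Also open, as far as these compounds go, is whether this carbon stays as undemanding with a very different group on the phenyl ring, such as an amine or a carboxylic acid, since the three compounds here carry only chloro, bromo and methoxy.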